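The source may report more compounds than this note shows. Statements on the series, on what has been measured and on what is new or still open speak of the compounds shown alone.

Three measured members of the series share one core, a cyclohexyl-bearing carbon carrying an oxime ether and an aryl ether, and differ in the heteroaryl ether and in the oxime side chain. Compound 1 `CC(/C=C/C(=O)O)=N\OC(c1ccc(OCc2ccc3ccccc3n2)cc1)C1CCCCC1` gives 40 nM in a functional assay for inhibition of Polyunsaturated fatty acid 5-lipoxygenase (Homo sapiens); a higher number here means a weaker inhibitor, a lower number a stronger inhibitor. Compound 2 `O=C(O)/C=N/OC(c1ccc(OCc2nc(-c3ccccc3)cs2)cc1)C1CCCCC1` gives 21 nM in this assay and stands second highest of the three numbers; its nearest neighbour is compound 3 `C/C(=N\OC(c1ccc(OCc2nc(-c3ccccc3)cs2)cc1)C1CCCCC1)C(=O)O` with 20 nM, its furthest compound 1. Going by the values given here, the only single-point step on record, a 1.1-fold lower number from compound 2 to compound 3 (0.02 log units; within the scatter), concerns the oxime side chain and not the aryl end. Compound 4 `CC(C)c1ccc(-c2csc(COc3ccc(C(O/N=C/C(=O)O)C4CCCCC4)cc3)n2)cc1` is not yet measured. It differs from compound 2 by isopropyl in place of hydrogen on an aromatic carbon. Among the compounds with values here, no measured step touches that ring, and compound 1 and compound 2 differ at the heteroaryl by more than one change, so their two values show only that such changes stayed within the scatter. For compound 4 a step of a 1.1-fold lower number from compound 2 to compound 4 (0.02 log units; within the scatter) is therefore expected, with no direction beyond the scatter. Compound 4 is estimated at 20 nM, within 7 nM to 60 nM.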

Compound 4, half-maximal inhibitory concentration: 35 nM
Estimate against measurement, compound 4: 1.8-fold (0.24 log units) below, within the range that was stated.
By their numbers in this assay, from the lowest: compounds 3, 2, 4 and 1 (each within the scatter of the next).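

In this assay, going by these compounds alone, the step of a 1.7-fold higher number from compound 2 to compound 4 (0.22 log units; within the scatter) is the first measured change on the outer phenyl ring, where the earlier compounds offered only a comparison that differed by more than one change. It shows that phenyl to 4-isopropylphenyl, with isopropyl placed para to a large group, does not move the number beyond the scatter, so this position can carry a group of 3 carbon atoms with no readable loss or gain in this series. Nothing available explains this result or connects it to any property of the group. With a single substituent at this position, the compounds shown do not tell whether a carboxylic acid, an amine or a longer chain such as n-hexyl would leave the number within the scatter as well. They also leave open whether isopropyl would read the same on the methyl-bearing oxime side chain of compound 3.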